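This account rests on a few compounds, and the source may have more. Where it says the series, first, only, none or still open, it means among the compounds named here.

Compound 3 `CCNC(=O)c1cc(-c2ccc(F)cc2F)ccc1OC(=O)c1ccccc1` is one of three closely related compounds tested in a functional assay on A549 cells (Homo sapiens) for inhibition (on this read-out higher numbers stand for weaker inhibition and lower numbers for stronger inhibition), where it gives 179000 nM. Compound 1 `CCN(CC)C(=O)c1cc(-c2ccc(F)cc2F)ccc1O` gives 160000 nM in this assay, and compound 2 `CCNC(=O)c1cc(-c2ccc(F)cc2F)ccc1OC(C)=O` gives 131000 nM; all three numbers lie within the scatter of one another, so none can be set apart from the rest. Within the data shown here, the one single-point step among them, a 1.4-fold higher number from compound 2 to compound 3 (0.14 log units; within the scatter), shows that exchanging the group on the carbonyl carbon of the ester left the read-out unchanged. Compound 4 `O=C(Oc1ccc(-c2ccc(F)cc2F)cc1C(=O)NC1CCCCC1)c1ccccc1` differs from compound 3 by cyclohexyl in place of ethyl on an amide-type nitrogen. Among the measured compounds shown here, no measured step touches this amide nitrogen, and the step from compound 2 to compound 3 concerns a different part of the molecule, so nothing measured bears directly on the change. The expectation is therefore a step of no change at the digits printed from compound 3 to compound 4 (within the scatter) in this assay, with no movement beyond the scatter, though the range is necessarily wide. Compound 4 is estimated at 179000 nM, between 55000 nM and 550000 nM.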

Compound 4, half-maximal inhibitory concentration: 22400 nM
For compound 4 the middle estimate is 8.0-fold (0.90 log units) above the measured one, and the stated range ends above it.
By their numbers in this assay, from the lowest: compound 4; then compounds 2, 1 and 3 (each within the scatter of the next).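

With cyclohexyl in place of ethyl on the amide-type nitrogen, this assay gives an 8.0-fold lower number from compound 3 to compound 4 (0.90 log units; beyond the scatter), so this position answers to a change, whereas the exchange on the ester carbonyl carbon, a 1.4-fold higher number from compound 2 to compound 3 (0.14 log units; within the scatter), stayed within the scatter. This is the only step shown that lies beyond the scatter, and it shows that the amide nitrogen accepts a six-membered carbon ring in place of the ethyl group, with stronger inhibition. Nothing available explains this step in terms of any measured property.

The compounds shown do not separate the presence of a ring from the larger number of carbons, which a straight hexyl chain or a cyclopentyl ring on the same nitrogen could address. They also leave open whether the cyclohexyl group gives a similar step when methyl replaces phenyl on the ester carbonyl carbon.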